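A Small Fluoro Change on Compound 3

This account rests on a few compounds, and the source may have more. Where it says the series, first, only, none or still open, it means among the compounds named here.

Values so far in an ADME assay (liver) for metabolic stability, with Liver microsome (Rattus norvegicus) as the target, using microsomes and NADPH, with a stated time of 30 min, tested at 1 uM (a higher number here means faster removal of the compound, a lower number slower removal), are these:
- compound 1 `Nc1ccc(S(=O)(=O)N2CCN(c3ncc(C(O)(C(F)(F)F)C(F)(F)F)cc3Br)CC2)cn1` gives 32 mL.min-1.g-1
- compound 2 `CS(=O)(=O)c1ccc(-c2cc(C(O)(C(F)(F)F)C(F)(F)F)cnc2N2CCN(S(=O)(=O)c3ccc(N)nc3)CC2)cc1` gives 103 mL.min-1.g-1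
- compound 3 `Nc1ccc(S(=O)(=O)N2CCN(c3ncc(C(O)(C(F)(F)F)C(F)(F)F)cc3-c3cccnc3)CC2)cn1` gives 20 mL.min-1.g-1

Compound 3 has the lowest number of the three, but this does not set it apart from every other compound. The comparison (a 1.6-fold lower number from compound 1 to compound 3 (0.20 log units; within the scatter)) leaves it level with compound 1, while the comparison (a 5.2-fold lower number from compound 2 to compound 3 (0.71 log units; beyond the scatter)) shows a clear gap to compound 2.

The next compound is compound 4 `Nc1ccc(S(=O)(=O)N2CCN(c3ncc(C(O)(C(F)(F)F)C(F)(F)F)cc3-c3cnccc3F)CC2)cn1` and it carries one small change: fluoro in place of hydrogen on an aromatic carbon, which turns pyridin-3-yl into 4-fluoropyridin-3-yl (fluoro in place of hydrogen on an aromatic carbon). Within the data shown here, no measured step adds fluoro, so the data offer no direct guide. The closest evidence comes from whole-group swaps at the same place on the shared core. Those steps were modest at most, as the largest (a 5.2-fold lower number from compound 2 to compound 3 (0.71 log units; beyond the scatter)) and the one for bromo to 4-(methylsulfonyl)phenyl (a 3.2-fold higher number from compound 1 to compound 2 (0.51 log units; beyond the scatter)) both show. A single added fluoro is a far smaller edit than either swap, so no step beyond the scatter is expected in this assay. The estimated step is a 1.1-fold higher number from compound 3 to compound 4 (0.04 log units; within the scatter) in this expectation. Compound 4 is expected at 22 mL.min-1.g-1 with an estimated range from 11 mL.min-1.g-1 to 45 mL.min-1.g-1 around that figure.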

Compound 4, intrinsic clearance in microsomes: 22 mL.min-1.g-1
Estimate against measurement, compound 4: no gap at the digits printed; the measured number falls inside the stated range.
By their numbers in this assay, from the lowest: compounds 3, 4 and 1 (each within the scatter of the next); then compound 2.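

In this assay, among these compounds, this is the first direct look at adding an atom to the pyridin-3-yl ring itself, and fluoro on this aromatic carbon, ortho to a large group and opposite the ring nitrogen, gives a step within the scatter (a 1.1-fold higher number from compound 3 to compound 4 (0.04 log units; within the scatter)), so no change can be read from it. The new 4-fluoropyridin-3-yl group also sits where pyridin-3-yl sat relative to the other two groups at this place: it is level with bromo (a 1.5-fold lower number from compound 1 to compound 4 (0.16 log units; within the scatter)) and clearly apart from 4-(methylsulfonyl)phenyl (a 4.7-fold lower number from compound 2 to compound 4 (0.67 log units; beyond the scatter)). Nothing available here offers an explanation for this result.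

The compounds shown leave open whether a bigger group on the same carbon, such as a methoxy group or an amine, would also stay level with the hydrogen of compound 3. They also leave open whether a chlorine atom in place of this fluoro, or fluoro on another carbon of the same ring, would give a step beyond the scatter.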